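Lengthening the ester tail on the urea nitrogen of compound 1

The source may hold more compounds than are shown below. What is called first, only, known or untested is meant among the compounds shown, and "the series" means these compounds.

For the measured compounds named here, compound 1, `CCOC(=O)NC(=O)NC1=CS(=O)(=O)O[C@@]12[C@@H](CO[Si](C)(C)C(C)(C)C)O[C@@H](n1cc(C)c(=O)n(C)c1=O)[C@@H]2O[Si](C)(C)C(C)(C)C`, is the only compound with a numeric reading in a functional assay on HEL cells (Homo sapiens) for cytotoxicity, read by microscopy (a lower number here means that less compound is tolerated, a higher number that more compound is tolerated), where compound 1 gives 16000 nM. Compound 2, `Cc1cn([C@@H]2O[C@@H]3COC(=O)[C@]3(OS(C)(=O)=O)[C@H]2O)c(=O)[nH]c1=O`, reaches only a limit of the assay: in this assay compound 2 shows >= 400000 nM. Going by the values given here, that limit, (the limit of >= 400000 nM in this assay, at which 1 of the 2 values shown sits), is the single other value at hand, so compound 1 stands alone as the one number to work from, with nothing to rank it against. Compound 3, `CCOC(=O)CNC(=O)NC1=CS(=O)(=O)O[C@@]12[C@@H](CO[Si](C)(C)C(C)(C)C)O[C@@H](n1cc(C)c(=O)n(C)c1=O)[C@@H]2O[Si](C)(C)C(C)(C)C`, has not yet been measured. It differs from compound 1 in one place: (ethoxycarbonyl)methyl in place of ethoxycarbonyl on an amide-type nitrogen. Among the compounds with values here, no measured pair in this set differs in a single place, so there is no measured step to guide the expectation. The step of no change at the digits printed from compound 1 to compound 3 (within the scatter) is therefore expected to stay within the usual scatter, with no direction preferred. Compound 3 is expected to give 16000 nM, in a range from 6000 nM to 45000 nM.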

Compound 3, minimum cytotoxic concentration: 16000 nM
Estimate against measurement, compound 3: no gap at the digits printed, within the range that was stated.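

In this assay, placing (ethoxycarbonyl)methyl on the amide-type nitrogen where compound 1 carries ethoxycarbonyl gives no change at the digits printed from compound 1 to compound 3 (within the scatter). For the compounds shown here, this is the first step in the set between compounds that differ in one place, so the position now has a reading of its own where the earlier compounds offered none. On the core of compound 1, the ester tail on this nitrogen can be lengthened by this one step without the reading leaving the scatter, though nothing at hand says why the reading holds.

On these data alone, whether a carboxylic acid in place of the ethyl ester, an amine, or a longer chain on this nitrogen would leave the reading where it stands remains open. Also open, as far as these compounds go, is whether the same change would read alike on a different core.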